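A few compounds are considered here, and "the series" means these few. Any claim that something is new, unique, unknown or untested is made for them only; others in the source may bear on it.

Compound 1, `COc1ccc(-c2cc(=O)c3c(OC)cc(OC)cc3n2Cc2ccccc2)cc1`, was tested in an ADME assay on BJ cells (Homo sapiens) for antiproliferative activity, with a stated time of 72 h; a higher number here means that more compound is needed for the effect, a lower number that less compound is needed. Here compound 1 gives only a limit, > 34400 nM, so where it stands among the measured compounds cannot be read off. Two related compounds were measured in the same way. Compound 2, `COc1ccc(-c2cc(=O)c3c(OC)cc(OC)cc3n2S(=O)(=O)c2c(F)c(F)c(F)c(F)c2F)cc1`, also gives a limit, > 34400 nM. Compound 3, `COc1ccc(-c2cc(=O)c3c(OC)cc(OC)cc3n2S(=O)(=O)c2cc(Cl)cc(Cl)c2O)cc1`, likewise gives a limit, > 37900 nM. The step that the two limits leave unreadable from compound 2 to compound 3 thus cannot be sized; the three values sit at the limit of > 34400 nM in this assay, at which 2 of the 3 values shown sit, and (the limit of > 37900 nM in this assay, at which 1 of the 3 values shown sits). Compound 4, `COc1ccc(-c2cc(=O)c3c(OC)cc(OC)cc3n2S(=O)(=O)c2ccc(OC)cc2)cc1`, carries (4-methoxyphenyl)sulfonyl in place of benzyl on an aromatic nitrogen. Within the data shown here, no measured step bears on this change, and every value shown is a limit. Compound 4 is expected to give about 50000 nM, between 15000 nM and 150000 nM, most likely again as a limit. The step that the limit leaves unreadable from compound 1 to compound 4 is expected to show nothing beyond the scatter.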

Compound 4, half-maximal effective concentration: > 82700 nM
Compound 4 ended at the assay's limit; the forecaster's own chance of this, stated with the estimate: 85%; middle value at least 1.6-fold (0.21 log units) from the limit.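

Compound 4 gives only a limit in this assay, as do compound 1, compound 2 and compound 3, so no step among these four can be read. On these data alone, what remains open is whether swapping these groups changes the effect at all.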